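Methoxycarbonyl to propoxycarbonyl: the step to compound 4

The source may report more compounds than this note shows. Statements on the series, on what has been measured and on what is new or still open speak of the compounds shown alone.

Measured in a functional assay on A549 cells (Homo sapiens) for antiproliferative activity, read by MTT assay, with a stated time of 48 h; on this read-out higher numbers stand for weaker inhibition of growth and lower numbers for stronger inhibition of growth:
- Compound 1 `COC(=O)N1N=C(c2cccc(OC)c2)CC1c1cc(OC)c(OC)c(OC)c1`: 2590 nM
- Compound 2 `CCCOC(=O)N1N=C(c2cccc(OC)c2)CC1c1cc(OC)c(OC)c(OC)c1`: > 10000 nM, a limit of the assay and not a number
- Compound 3 `COC(=O)N1N=C(c2cccc(O)c2)CC1c1cc(OC)c(OC)c(OC)c1`: 3170 nM

Compound 3 at 3170 nM stands within the scatter of compound 1, as a 1.2-fold higher number from compound 1 to compound 3 (0.09 log units; within the scatter) shows. That step puts hydrogen in place of methyl on an oxygen on an aromatic ring.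

Compound 4 `CCCOC(=O)N1N=C(c2cccc(O)c2)CC1c1cc(OC)c(OC)c(OC)c1` is reached from compound 3 through (ethyl in place of hydrogen on a saturated chain carbon bound to an oxygen next to a carbonyl group); the same difference reads methoxycarbonyl to propoxycarbonyl. This change has been measured once in the series, as an at least 3.8-fold higher number from compound 1 to compound 2 (0.58 log units; beyond the scatter). That step ends at a limit, (the limit of > 10000 nM in this assay, at which 1 of the 3 values shown sits), so its size is known only from one side. Going by the values given here, with only this one measured example, a step of similar size towards weaker inhibition is expected in this assay, and compound 2 is the basis for this through an at least 3.8-fold higher number from compound 1 to compound 2 (0.58 log units; beyond the scatter). The expected change is a 4.1-fold higher number from compound 3 to compound 4 (0.61 log units; beyond the scatter). A report as a limit alone is also likely. For compound 4 the estimated value is 13000 nM, with an expected range from 6000 nM to 30000 nM.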

Compound 4, concentration for 50% growth inhibition: > 10000 nM
Compound 4: only a limit was reported; the forecaster's own chance of this, stated with the estimate: 75%; the middle value lies beyond the limit too.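

The change from methoxycarbonyl to propoxycarbonyl now gives weaker inhibition of growth on a second core in this assay, with an at least 3.1-fold higher number from compound 3 to compound 4 (0.49 log units; beyond the scatter). The loss of activity therefore no longer rests on a single pair, and it appears both with the methoxy group on the aromatic ring and with the hydroxyl group that replaces it: the same change on two cores in this assay, an at least 3.8-fold higher number (0.58 log units; beyond the scatter) from compound 1 to compound 2 and an at least 3.1-fold higher number (0.49 log units; beyond the scatter) from compound 3 to compound 4; the limit leaves it open whether they differ. Among the propoxycarbonyl compounds, the effect of hydrogen in place of methyl on an oxygen on an aromatic ring cannot be read, because both ends of that step are limits: the limit of > 10000 nM in this assay, at which 2 of the 4 values shown sit.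

As far as these compounds go, both readable steps end at a limit, so how far activity falls on either core stays open, as does any difference between the two cores. Also open, from the compounds shown here alone, is how an ethoxycarbonyl group, which would show whether a shorter chain than propyl is tolerated at this position, or a carboxylic acid in place of the ester, would read in this assay.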